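A few compounds are considered here, and "the series" means these few. Any claim that something is new, unique, unknown or untested is made for them only; others in the source may bear on it.

The measured compounds:
compound 1, `CS(=O)(=O)c1cccc(S(=O)(=O)c2ccc3c(c2)CCC[C@H]3CN)c1`, which in an assay on isolated protein for displacement of a labelled ligand from 5-hydroxytryptamine receptor 6 (Homo sapiens) (on this read-out lower numbers stand for stronger inhibition and higher numbers for weaker inhibition), gives 3.98 nM;
compound 2, `Cn1ccc(S(=O)(=O)c2ccc3c(c2)CCC[C@H]3CN)c1`, which in this assay gives 7.94 nM;
compound 3, `COCCNC[C@@H]1CCCc2cc(S(=O)(=O)c3cccc(F)c3)ccc21`, which in this assay gives 0.251 nM.

Compound 3 stands lowest of the three numbers. Its nearest neighbour is compound 1, whose number is higher by a gap beyond the usual scatter, and compound 2 lies furthest away, also beyond the scatter. Compound 4, `CS(=O)(=O)NC[C@@H]1CCCc2cc(S(=O)(=O)c3cccc(F)c3)ccc21`, has not yet been measured in this assay. It differs from compound 3 in a single place: methylsulfonyl in place of 2-methoxyethyl on an amine nitrogen. Going by the values given here, none of the measured pairs differ in one place, so no measured step exists to guide the expectation, and none of the three measured compounds carries a methylsulfonyl on the amine nitrogen. The account therefore rests on the structural change alone. Compound 4 is expected to give a higher number than compound 3, a step of a 400-fold higher number from compound 3 to compound 4 (2.60 log units; beyond the scatter) that is expected to lie beyond the scatter. Compound 4 is estimated at 100 nM, with a range from 10 nM to 1000 nM.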

Compound 4, inhibition constant: 0.2 nM
Estimate against measurement, compound 4: 500-fold (2.70 log units) above, outside the stated range (below it).
By their numbers in this assay, from the lowest: compounds 4 and 3 (each within the scatter of the next); then compounds 1 and 2 (each within the scatter of the next).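

In this assay, putting methylsulfonyl in place of 2-methoxyethyl on the amine nitrogen gives a 1.3-fold lower number from compound 3 to compound 4 (0.10 log units; within the scatter), so the two compounds cannot be told apart on this read-out. Going by these compounds alone, this is the first measured step at this nitrogen, and it shows that the swap leaves the number unchanged within the scatter, even though the entering group brings a sulfur, two double bonds outside aromatic rings and a second hydrogen-bond acceptor. No measurement shown here accounts for why these two groups read alike.

The compounds shown leave open whether an acetyl group, a longer chain such as 3-methoxypropyl, or a plain hydrogen on this nitrogen would read the same on this core. Compound 1 and compound 2 differ from compound 3 and compound 4 in more than one place, so they cannot settle this.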